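This account rests on a few compounds, and the source may have more. Where it says the series, first, only, none or still open, it means among the compounds named here.

In a functional assay on HeLa cells (Homo sapiens) for cytotoxicity, read by ELISA, with a stated time of 4 days (on this read-out higher numbers stand for weaker inhibition and lower numbers for stronger inhibition), compound 1 `Cc1ccsc1-c1cc(-c2ccoc2)cc(-c2ccco2)n1` gives 30500 nM, within the scatter of both other measured compounds: compound 2 `Cc1ccsc1-c1cc(-c2ccoc2)cc(-c2ccc(Cl)cc2)n1` gives 17400 nM and compound 3 `Clc1ccc(-c2cc(-c3ccco3)cc(-c3ccc(Cl)s3)n2)cc1` gives 17000 nM. Compound 4 `Clc1ccc(-c2cc(-c3ccoc3)cc(-c3ccco3)n2)s1` carries 5-chlorothiophen-2-yl in place of 3-methylthiophen-2-yl on an aromatic carbon, next to the ring nitrogen (5-chlorothiophen-2-yl in place of 3-methylthiophen-2-yl on an aromatic carbon). Among the compounds with values here, the only measured step, a 1.8-fold lower number from compound 1 to compound 2 (0.24 log units; within the scatter), lies at a different place and stays within the scatter. Within the data shown here, the entering group also occurs in compound 3, at 17000 nM, but no measured step isolates it. No step beyond the scatter is therefore expected in this assay. The expected step is a 1.3-fold lower number from compound 1 to compound 4 (0.10 log units; within the scatter). For compound 4 the estimated value is 24000 nM, with an expected range from 12000 nM to 50000 nM.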

Compound 4, half-maximal inhibitory concentration: 22700 nM
For compound 4 the middle estimate is 1.1-fold (0.02 log units) above the measured one; the measured number falls inside the stated range.
By their numbers in this assay, from the lowest: compounds 3, 2, 4 and 1 (each within the scatter of the next).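

In this assay, 5-chlorothiophen-2-yl in place of 3-methylthiophen-2-yl on the aromatic carbon next to the ring nitrogen gives a 1.3-fold lower number from compound 1 to compound 4 (0.13 log units; within the scatter). Within the data shown here, this is the first measured step at this position, and it shows that exchanging one substituted thiophene for the other leaves the number within the scatter. No measurement shown bears on the reason for this result. The compounds shown leave open whether an amine or a carboxylic acid on this carbon, in place of the thiophene, would move the number beyond the scatter.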